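A few compounds are considered here, and "the series" means these few. Any claim that something is new, unique, unknown or untested is made for them only; others in the source may bear on it.

Measured so far:
- compound 1, `Cc1cc2c(c3c1C[C@@H]1[C@@H](C)CO[C@]1(C)O3)C[C@@H]1[C@@H](C)CO[C@]1(C)O2`: 40000 nM
- compound 2, `CC1COC2(C)Oc3cc(O)c4c(c3CC12)OC1(C)OCC(C)C1C4`: 19000 nM

Both compounds were tested in a functional assay on aorta (Rattus norvegicus, strain Sprague-Dawley) for inhibition; on this read-out lower numbers stand for an effect already at smaller amounts and higher numbers for an effect only at larger amounts of compound. Compound 1 gives 40000 nM, the higher of the two numbers, so it acts only at larger amounts than compound 2, which gives 19000 nM, a difference that lies beyond the usual scatter.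

Compound 3, `C[C@H]1CO[C@]2(C)Oc3cc(OC/C=C/c4ccccc4)c4c(c3C[C@H]12)O[C@@]1(C)OC[C@H](C)[C@H]1C4`, has not been measured. It differs from compound 1 in one place: (3-phenylprop-2-en-1-yl)oxy in place of methyl on an aromatic carbon. A single carbon on the shared core is thus replaced by a far larger group that also brings an aromatic ring and a double bond.

No comparable change has been measured within this set, so the expectation for this step rests on the weak starting point of compound 1 at 40000 nM alone. A moderate move toward smaller amounts is expected, a 2.7-fold lower number from compound 1 to compound 3 (0.43 log units; beyond the scatter), with wide uncertainty. Compound 3 is therefore estimated at 15000 nM, within a range from 4000 nM to 60000 nM.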

Compound 3, half-maximal effective concentration: 64000 nM
Compound 3: the middle estimate sits 4.3-fold (0.63 log units) below what was measured, and the stated range ends below it.
By their numbers in this assay, from the lowest: compound 2; then compounds 1 and 3 (each within the scatter of the next).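

In this assay, (3-phenylprop-2-en-1-yl)oxy in place of methyl on this aromatic carbon gives a 1.6-fold higher number from compound 1 to compound 3 (0.20 log units; within the scatter), so the two compounds cannot be told apart on this read-out. For the compounds shown here, this position of the shared core therefore takes a far larger group, one that brings an aromatic ring and a double bond, with no step beyond the usual scatter, and that is something the earlier compounds could not show. Nothing measured here offers an explanation for this result.

Still open, on these data alone, is whether a group of a different kind on this aromatic carbon, such as an amine or a carboxylic acid, would give a number clearly apart from these. As far as these compounds go, a shorter chain such as methoxy, or a saturated chain such as 3-phenylpropoxy, is equally open.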